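This account rests on a few compounds, and the source may have more. Where it says the series, first, only, none or still open, it means among the compounds named here.

Two compounds share one core. Compound 1 `Cc1ccc2nc(C)n(NC(=O)/C(C#N)=C/c3ccc(O)cc3)c(=O)c2c1` carries an unsaturated nitrile-bearing amide, and in a functional assay on HepG2 cells (Homo sapiens) for cytotoxicity, read by MTT assay, with a stated time of 3 days (on this read-out higher numbers stand for weaker inhibition and lower numbers for stronger inhibition), compound 1 gives 13000 nM. Compound 2 `Cc1ccc2nc(C)n(NC(=O)c3sc(=S)n(-c4ccccc4)c3N)c(=O)c2c1` carries instead a five-membered sulfur-containing ring bearing an amino group and a phenyl on its nitrogen; in this assay compound 2 gives 27000 nM. Compound 2 therefore stands at the higher of the two numbers, and its distance from compound 1 lies beyond the usual scatter.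

Compound 3 `Cc1ccc2nc(C)n(NC(=O)c3sc(=S)n(Cc4ccccc4)c3N)c(=O)c2c1` has not yet been measured. It differs from compound 2 in one place: benzyl in place of phenyl on an aromatic nitrogen. For the measured compounds named here, no measured pair shows what such an exchange does on this core, so the step is expected to be small, with no direction beyond the scatter: a 1.1-fold lower number from compound 2 to compound 3 (0.03 log units; within the scatter). On that basis compound 3 is expected to give about 25000 nM in this assay, within a range from 10000 nM to 60000 nM.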

Compound 3, half-maximal inhibitory concentration: 32000 nM
Compound 3: the middle estimate sits 1.3-fold (0.11 log units) below what was measured; low and high end bracket the measured number.
By their numbers in this assay, from the lowest: compound 1; then compounds 2 and 3 (each within the scatter of the next).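

In this assay, for the compounds shown here, compounds 2 and 3 form the first pair on the shared core that differs in one place, and the exchange gives a 1.2-fold higher number from compound 2 to compound 3 (0.07 log units; within the scatter). On an aromatic nitrogen of this five-membered ring, benzyl in place of phenyl keeps the six-membered aromatic ring of carbon only and leaves the two compounds indistinguishable on this read-out, so this one exchange at this position does not separate them. Nothing measured here bears on why the exchange leaves the number in place.

From the compounds shown here alone, it remains open whether a methyl group or a longer chain on this nitrogen, or a phenyl carrying an amine or a carboxylic acid, would move the number beyond the scatter. Also open, going by these compounds, is what replacing the amino group with a hydroxyl or a methyl group would do.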